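This account rests on a few compounds, and the source may have more. Where it says the series, first, only, none or still open, it means among the compounds named here.

Measured so far in an assay on COS-7 cells for inhibition of patatin-like phospholipase domain-containing protein 2 (Mus musculus); a higher number here means a weaker inhibitor, a lower number a stronger inhibitor:
- compound 1 `CCOC(=O)c1cccc(-c2ccc(OCC)cc2)c1`: 50000 nM
- compound 2 `CCOc1ccc(-c2cccc(C(=O)N3CCCC3)c2)cc1`: 160000 nM

Both numbers are high; the series is weak throughout. Compound 2 holds the highest number of the two, with compound 1 the nearest at a 3.2-fold higher number from compound 1 to compound 2 (0.51 log units; beyond the scatter), the change there being pyrrolidin-1-yl in place of ethoxy on the carbonyl carbon.

Compound 3 `CCNC(=O)c1cccc(-c2ccc(OCC)cc2)c1` is the next step from compound 2: ethylamino in place of pyrrolidin-1-yl on a carbonyl carbon. Within the data shown here, no measured pair covers exactly this change. Among the measured compounds shown here, the only step that bears on it is the one from compound 1 to compound 2, which shows that the amide of compound 2 sits modestly above the ester of compound 1; compound 3 keeps an amide at the same carbonyl but with a smaller, open-chain group that brings one hydrogen-bond donor. For the measured compounds named here, with a single related step and no precedent for the donor, the expectation is a step of about a 1.6-fold lower number from compound 2 to compound 3 (0.20 log units; within the scatter), that is, no move beyond the scatter or at most a small lowering toward the number of compound 1. The estimate for compound 3 in this assay is therefore 100000 nM, with a range of 40000 nM to 250000 nM.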

Compound 3, half-maximal inhibitory concentration: 90000 nM
Compound 3: the middle estimate sits 1.1-fold (0.05 log units) above what was measured, within the range that was stated.
By their numbers in this assay, from the lowest: compounds 1, 3 and 2 (each within the scatter of the next, the first and the last beyond it).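

In this assay the exchange of pyrrolidin-1-yl for ethylamino on the carbonyl carbon gives a 1.8-fold lower number from compound 2 to compound 3 (0.25 log units; within the scatter) and so the loss of the ring together with the arrival of the amide hydrogen cannot be told apart from no change at this position. Set against the ethoxy of the ester, the same ethylamino gives a 1.8-fold higher number from compound 1 to compound 3 (0.26 log units; within the scatter) and compound 3 is therefore separated from neither of the other two compounds, while a 3.2-fold higher number from compound 1 to compound 2 (0.51 log units; beyond the scatter) stays the only step here that lies beyond the scatter. Nothing available accounts for these values or tells what the ethylamino group contributes.

Dimethylamino on the same carbonyl carbon would separate the removal of the ring from the presence of the amide hydrogen, a pairing the three compounds cannot provide. Also open, as far as these compounds go, is whether any group on this carbonyl carbon, such as the hydroxyl of a carboxylic acid or a longer chain like butylamino, takes the series clearly out of its weak range.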